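This account rests on a few compounds, and the source may have more. Where it says the series, first, only, none or still open, it means among the compounds named here.

Compound 1 `COc1ccc(OC)c(/C=N/NC(=O)Nc2ccc(Oc3ccnc(-c4nncn4CCN(C)C)c3)c(F)c2)c1`: 2070 nM
Compound 2 `CN(C)CCn1cnnc1-c1cc(Oc2ccc(NC(=O)N/N=C/c3cccc(Br)c3)cc2F)ccn1`: 380 nM

In a functional assay on HT-29 cells (Homo sapiens) for cytotoxicity, read by MTT assay, with a stated time of 72 h (on this read-out lower numbers stand for stronger inhibition and higher numbers for weaker inhibition), compound 2 gives 380 nM. Compound 1 gives 2070 nM. Among the compounds with values here, of these two measured compounds, compound 2 has the lower number, and the single measured step runs toward it: a 5.4-fold lower number from compound 1 to compound 2 (0.74 log units; beyond the scatter). Compound 3 `CN(C)CCn1cnnc1-c1cc(Oc2ccc(NC(=O)N/N=C/c3cccc(O)c3)cc2F)ccn1` keeps the whole framework of compound 2 and changes one point: hydroxy in place of bromo on an aromatic carbon. Read one bond further out, this is 3-bromophenyl becoming 3-hydroxyphenyl. Within the data shown here, no measured step exchanges bromo for hydroxy, so nothing bears on this change directly. Among the measured compounds shown here, the step from compound 1 to compound 2 shows only that the choice of group on this ring can move the number by a modest amount in this assay; it gives no direction for the present exchange. For the measured compounds named here, with one comparison and no matching precedent, the expectation for compound 3 is a rise in the number of moderate size, a 2.6-fold higher number from compound 2 to compound 3 (0.42 log units; beyond the scatter), carrying wide uncertainty. Compound 3 is therefore estimated at 1000 nM, with a range from 300 nM to 4000 nM.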

Compound 3, half-maximal inhibitory concentration: 330 nM
Estimate against measurement, compound 3: 3.0-fold (0.48 log units) above, and the stated range covers the measured number.
By their numbers in this assay, from the lowest: compounds 3 and 2 (each within the scatter of the next); then compound 1.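

In this assay, exchanging bromo for hydroxy gives a 1.2-fold lower number from compound 2 to compound 3 (0.06 log units; within the scatter) and so leaves compound 2 and compound 3 indistinguishable, even though hydroxy brings a hydrogen-bond donor and a hydrogen-bond acceptor that bromo does not. The comparison with 2,5-dimethoxyphenyl now has a second member, with a 6.3-fold lower number from compound 1 to compound 3 (0.80 log units; beyond the scatter) beyond the scatter, so both compounds carrying a single group on this ring have clearly lower numbers than compound 1. Nothing measured here explains why these two very different groups give matching numbers.

The compounds shown leave open how far this tolerance extends: an amine, a carboxylic acid or a longer chain at the same place could match these numbers or depart from them. They also cannot separate the roles of the two methoxy groups of compound 1, and a ring with a single methoxy group would be needed to show whether either one alone goes with the higher number.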